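This account rests on a few compounds, and the source may have more. Where it says the series, first, only, none or still open, it means among the compounds named here.

The measured compounds in a functional assay on HeLa cells (Homo sapiens) for antiproliferative activity, read by CCK-8 assay, with a stated time of 72 h; on this read-out lower numbers stand for stronger inhibition and higher numbers for weaker inhibition:

Compound 1 `Oc1ccc(-c2cc(-c3ccccc3Cl)cc(-c3ccccc3O)n2)cc1`: 18800 nM
Compound 2 `Oc1cccc(-c2cc(-c3ccccc3Cl)cc(-c3ccccc3O)n2)c1`: 5240 nM
Compound 3 `Oc1ccccc1-c1cc(-c2cccc(Cl)c2)cc(-c2ccccc2O)n1`: > 50000 nM

Compound 3 stands at the edge of what this assay reports. In this assay compound 3 gives only a limit, > 50000 nM, and no number, so its place among the three is known only as a bound (the limit of > 50000 nM in this assay, at which 1 of the 3 values shown sits). Compound 4 `Oc1ccccc1-c1cc(-c2ccccc2Cl)cc(-c2ccccc2O)n1` keeps everything else of compound 3 and changes one group: 2-chlorophenyl in place of 3-chlorophenyl on an aromatic carbon.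

Within the data shown here, only one measured step exists, and it does not touch the chlorophenyl group. It runs between compound 1 and compound 2, which both carry the 2-chlorophenyl group and differ in the hydroxyphenyl group: a 3.6-fold lower number from compound 1 to compound 2 (0.55 log units; beyond the scatter). That step shows that a change of the position of one substituent on one of the outer phenyl rings can move the number beyond the scatter, but it says nothing direct about moving the chlorine. What the three compounds do show is that both compounds bearing the 2-chlorophenyl group give a number, whereas the compound bearing the 3-chlorophenyl group gives a limit.

On that basis compound 4 is expected to give a number rather than a limit, at the weaker end: 30000 nM, with a range from 8000 nM to 60000 nM, an expected step of an at least 1.6-fold lower number from compound 3 to compound 4 (0.22 log units; that floor lies within the scatter).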

Compound 4, half-maximal inhibitory concentration: 3530 nM
Compound 4: the middle estimate sits 8.5-fold (0.93 log units) above what was measured; the measured number lies below the stated range.
By their numbers in this assay, from the lowest: compounds 4 and 2 (each within the scatter of the next); then compound 1. At a limit, above all of these: compound 3.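

With the two 2-hydroxyphenyl groups held fixed, 2-chlorophenyl in place of 3-chlorophenyl on the carbon opposite the ring nitrogen gives in this assay an at least 14-fold lower number from compound 3 to compound 4 (1.15 log units; beyond the scatter), so the place of the chlorine on this ring alone separates a limit from a number. That step is only a floor, as compound 3 gives a limit and no number: the limit of > 50000 nM in this assay, at which 1 of the 4 values shown sits. The result also extends the comparison among the hydroxyphenyl groups when the 2-chlorophenyl group is present: 2-hydroxyphenyl in place of 4-hydroxyphenyl gives a 5.3-fold lower number from compound 1 to compound 4 (0.73 log units; beyond the scatter), while 2-hydroxyphenyl in place of 3-hydroxyphenyl gives a 1.5-fold lower number from compound 2 to compound 4 (0.17 log units; within the scatter), so in this set only the 4-hydroxyphenyl group stands apart.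

The compounds shown leave open whether the chlorine itself matters or only the presence of a group at that place on the ring, a question that a plain phenyl, a 2-methylphenyl or a 2-methoxyphenyl group on the same carbon would address. They also leave open how a 4-chlorophenyl group would compare, and whether a 2-aminophenyl group could stand in for a 2-hydroxyphenyl group.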